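The source may report more compounds than this note shows. Statements on the series, on what has been measured and on what is new or still open speak of the compounds shown alone.

Compound 1 `O=C(Nc1ccccc1)Nc1nc(Nc2ccccc2)cc(Sc2c[nH]c3ccccc23)n1`: 14400 nM in a functional assay on HepG2 cells (Homo sapiens) for inhibition, with a stated time of 72 h; on this read-out lower numbers stand for stronger inhibition and higher numbers for weaker inhibition
Compound 2 `O=C(Nc1ccc(Cl)cc1)Nc1nc(Sc2c[nH]c3ccccc23)cc(N2CCCCC2)n1`: 14800 nM in this assay
Compound 3 `Cc1ccc(NC(=O)Nc2nc(Nc3ccccc3)cc(Sc3c[nH]c4ccccc34)n2)cc1`: 14900 nM in this assay

All three numbers from compound 1, compound 2 and compound 3 lie within the scatter of one another, so compound 3 cannot be set apart from either of the other two. For the measured compounds named here, the one measured step that bears on the next change is a 1.0-fold higher number from compound 1 to compound 3 (0.01 log units; within the scatter), a small substituent added to the phenyl on the urea, which left the number unchanged. Compound 4 `Cc1cc(Cl)ccc1NC(=O)Nc1nc(Nc2ccccc2)cc(Sc2c[nH]c3ccccc23)n1` carries the change (4-chloro-2-methylphenyl in place of 4-methylphenyl on an amide-type nitrogen). Going by the values given here, no measured pair tests a chlorine at this site; compound 2 has a chlorine on its urea phenyl but differs in a second place as well, so its value alone says nothing about this step. The expected step of a 1.1-fold lower number from compound 3 to compound 4 (0.03 log units; within the scatter) is therefore none beyond the scatter, and compound 4 is estimated at 14000 nM, between 6000 nM and 35000 nM.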

Compound 4, half-maximal inhibitory concentration: 8370 nM
Compound 4: middle estimate off by 1.7-fold (0.22 log units), on the high side, within the range that was stated.
By their numbers in this assay, from the lowest: compounds 4, 1, 2 and 3 (each within the scatter of the next).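

The first direct test of chlorine at this position gives a 1.8-fold lower number from compound 3 to compound 4 (0.25 log units; within the scatter), and replacing the unsubstituted phenyl gives a 1.7-fold lower number from compound 1 to compound 4 (0.24 log units; within the scatter) in this assay. Compound 4 therefore cannot be told apart from compound 1 or compound 3, even with both a chlorine and a second methyl on the ring. No measured evidence on the cause of these numbers is available.

On these data alone, what the chlorine and the second methyl each contribute alone remains open. So does whether an amine or a carboxylic acid on this phenyl would move the number beyond the scatter.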